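From phenyl to 3-(trifluoromethyl)phenyl in compound 3

The source may hold more compounds than are shown below. What is called first, only, known or untested is meant among the compounds shown, and "the series" means these compounds.

Measured so far in a functional assay (thoracic aorta) for inhibition, with Rattus norvegicus as the target (a lower number here means a stronger inhibitor, a higher number a weaker inhibitor), are these compounds:
Compound 1 `O=C(O)c1cc(CCCCNS(=O)(=O)c2ccccc2)c2cccccc1-2` gives 570 nM
Compound 2 `O=C(O)c1cc(CCCCCCCCNS(=O)(=O)c2ccccc2)c2cccccc1-2` gives 38 nM
Compound 3 `CC(C)c1ccc2c(CCCCNS(=O)(=O)c3ccccc3)cc(C(=O)O)c-2cc1` gives 70 nM

Compound 3 lies within the usual scatter of compound 2 and well under compound 1 in this assay on this scale. Compound 4 `CC(C)c1ccc2c(CCCCNS(=O)(=O)c3cccc(C(F)(F)F)c3)cc(C(=O)O)c-2cc1` differs from compound 3 by one change, trifluoromethyl in place of hydrogen on an aromatic carbon, so phenyl becomes 3-(trifluoromethyl)phenyl.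

Among the measured compounds shown here, no measured pair changes this phenyl. For the measured compounds named here, the nearest guide is an 8.1-fold lower number from compound 1 to compound 3 (0.91 log units; beyond the scatter) when isopropyl replaces hydrogen on an aromatic carbon, but that step lies elsewhere in the molecule and shows only that one added group can matter. With a single step of a different kind as evidence, no firm direction can be argued. The expected result is a 1.2-fold lower number from compound 3 to compound 4 (0.07 log units; within the scatter) in this assay and so no change beyond the scatter. For compound 4 the estimate is 60 nM with an expected range from 18 nM to 200 nM in this measurement.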

Compound 4, half-maximal inhibitory concentration: 1600 nM
Estimate against measurement, compound 4: 27-fold (1.43 log units) below, outside the stated range (above it).
By their numbers in this assay, from the lowest: compounds 2 and 3 (each within the scatter of the next); then compound 1; then compound 4.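

In this assay, the phenyl group proves sensitive to substitution: adding trifluoromethyl on its aromatic carbon gives a 23-fold higher number from compound 3 to compound 4 (1.36 log units; beyond the scatter), a large loss of inhibitory strength. Among the compounds shown here, the one earlier change of a hydrogen on an aromatic carbon, an 8.1-fold lower number from compound 1 to compound 3 (0.91 log units; beyond the scatter), went the other way, so adding a group to an aromatic carbon does not by itself strengthen these compounds, and the result at one place does not carry over to another. Nothing measured here explains the loss.

A single group at this place cannot show whether the loss belongs to trifluoromethyl or would follow any added group, and a methyl group, a chlorine atom or an amine at the same place would help to tell these apart. Going by these compounds, it also remains open whether the same change would cost as much on the longer chain of compound 2.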